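One Methyl Added, Little Change Expected

This account rests on a few compounds, and the source may have more. Where it says the series, first, only, none or still open, it means among the compounds named here.

Of the compounds shown here, two built on a shared core have already been measured. Compound 1 `C=C1CC[C@H]2C(C)(C)CCC[C@]2(C)[C@H]1C[C@@H](O)C1=CCOC1=O` and compound 2 `C=C1CC[C@H]2C(C)(C)CCC[C@]2(C)[C@H]1C/C=C1\CC(O)OC1=O` were both run in a functional assay on RAW264.7 cells (Mus musculus) for inhibition, read by ELISA, with stated times of 1 h and 18 h, tested at 0.1 uM; a lower number here means a stronger effect, a higher number a weaker effect of the compound at the concentration tested. In that test compound 1 gives 101%, and compound 2 gives 99.1%. The two numbers lie within the scatter of each other, so compound 2 stands level with compound 1, and at the tested concentration neither compound shifts the read-out away from where an untreated sample would sit. Compound 3 `C=C1CC[C@H]2C(C)(C)CCC[C@]2(C)[C@H]1C/C=C1\CC(OC)OC1=O` is the next compound in line and has not yet been measured in this assay. It differs from compound 2 in one place: methyl in place of hydrogen on an oxygen on a saturated carbon. Among the measured compounds shown here, no measured pair shows what this change does, and the two known numbers both signal no effect, so compound 3 is expected to stay where compound 2 is, with a step of a number 1.1 percentage points lower from compound 2 to compound 3 (within the scatter), none beyond the scatter. For compound 3 the estimate is 98%, within a range from 85% to 110%.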

Compound 3, a percentage reported as activity, at one concentration (the size of the read-out at that concentration, not a potency): 101%
Beside the measured number, compound 3's estimate is 3 percentage points below it, within the range that was stated.
By their numbers in this assay, from the lowest: compounds 2, 1 and 3 (each within the scatter of the next).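

Among the compounds shown here, this pair gives the first reading of the change from hydroxy to methoxy on a saturated carbon: methyl in place of hydrogen on that oxygen comes with a number 1.9 percentage points higher from compound 2 to compound 3 (within the scatter) in this assay. Compound 3 therefore sits with compound 2 at the level of no effect, which shows only that adding this methyl does not bring out an effect at the one concentration tested, not that the position tolerates every change. Nothing available explains this result.

On these data alone, whether a larger group at this place, such as an ethoxy group or an amine in place of the hydroxy, would move the read-out away from the no-effect level remains open. Also open, as far as these compounds go, is whether hydroxy and methoxy would still read alike at a higher concentration, where an effect might appear.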